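A few compounds are considered here, and "the series" means these few. Any claim that something is new, unique, unknown or untested is made for them only; others in the source may bear on it.

Values from a functional assay on DLD-1 cells (Homo sapiens) for antiproliferative activity, read by CellTiter-Glo, with a stated time of 72 h (a lower number here means a stronger inhibitor, a higher number a weaker inhibitor), follow
Compound 1 `CC1CCN(C2CCN(S(=O)(=O)c3ccc(Cl)nc3)CC2)CC1` gives 3700 nM
Compound 2 `CC1CCN(C2CCN(S(=O)(=O)c3cccc(Cl)c3)CC2)CC1` gives > 5000 nM (a limit of the assay and not a number)
Compound 3 `CC1CCN(C2CCN(S(=O)(=O)c3ccc(F)cc3F)CC2)CC1` gives 102 nM

Compound 3 is the strongest inhibitor of the three, and even the nearest number lies well away (a 36-fold lower number from compound 1 to compound 3 (1.56 log units; beyond the scatter)). The unmeasured compound 4 `CC1CCN(C2CCN(S(=O)(=O)c3cc(Cl)cc(Cl)c3)CC2)CC1` keeps the shared core and differs only in the group on the sulfonyl sulfur (3,5-dichlorophenyl in place of 2,4-difluorophenyl on a sulfonyl sulfur), where 3,5-dichlorophenyl takes the place of 2,4-difluorophenyl.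

Among the measured compounds shown here, three measured steps bear on this change, all of them at the same sulfonyl sulfur. Replacing the 3-chlorophenyl of compound 2 with 2,4-difluorophenyl gave a large step (an at least 49-fold lower number from compound 2 to compound 3 (1.69 log units; beyond the scatter)). The step between the two chlorine-bearing groups was small (an at least 1.3-fold higher number from compound 1 to compound 2 (0.13 log units; that floor lies within the scatter)). For the measured compounds named here, no measured compound carries 3,5-dichlorophenyl, so the closest guide is the 3-chlorophenyl of compound 2, and a large move to a higher number is expected on leaving 2,4-difluorophenyl. The expected step is a 20-fold higher number from compound 3 to compound 4 (1.29 log units; beyond the scatter) in this assay and it points to a weaker inhibitor. The estimated value of compound 4 is 2000 nM with an expected range from 300 nM to 5000 nM in this measurement. Compound 4 may also return only a limit.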

Compound 4, half-maximal inhibitory concentration: 3400 nM
Beside the measured number, compound 4's estimate is 1.7-fold (0.23 log units) below it, within the range that was stated.
By their numbers in this assay, from the lowest: compound 3; then compounds 4 and 1 (each within the scatter of the next). At a limit, above all of these: compound 2.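

In this assay, 3,5-dichlorophenyl on the sulfonyl sulfur does not keep the result seen with 2,4-difluorophenyl (a 33-fold higher number from compound 3 to compound 4 (1.52 log units; beyond the scatter)), although the two groups match in heavy atoms, hydrogen-bond donors and hydrogen-bond acceptors, so those counts alone do not set the result at this position. 3,5-Dichlorophenyl and 6-chloropyridin-3-yl cannot be told apart in this assay (a 1.1-fold lower number from compound 1 to compound 4 (0.04 log units; within the scatter)), and all three chlorine-bearing groups shown lie well away from the one fluorine-bearing group, with no compound here going against that pattern. Compound 2 gives only a limit of the assay and not a number, so adding chloro in place of hydrogen on an aromatic carbon can be read only as a floor that stays within the scatter (an at least 1.4-fold lower number from compound 2 to compound 4 (0.16 log units; that floor lies within the scatter)): the limit of > 5000 nM in this assay, at which 1 of the 4 values shown sits.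

Among the compounds shown here, compound 3 is the only compound with fluorine, so these compounds cannot separate the effect of fluorine itself from the effect of its placement on the ring. Going by these compounds, how a 3,5-difluorophenyl, an unsubstituted phenyl or a methoxy-bearing phenyl group would compare at the sulfonyl sulfur also remains open.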